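The compounds below may be only part of what the source reports. "The series", "measured", "known", "first", "only" and "open" are said of these compounds alone.

Among the compounds with values here, in a functional assay on a cell-free system (plasma, Homo sapiens), with a stated time of 3 min (on this read-out higher numbers stand for weaker inhibition and lower numbers for stronger inhibition), compound 1 (`O=C(NCc1cc(Cl)ccc1-n1cnnn1)[C@@H]1C[C@@H]2C[C@@H]2N1C(=O)[C@H](O)C1CCCCC1`) gives 600 nM and so holds the lower of the two numbers measured so far. Compound 2 (`CC(C)(C)[C@@H](O)C(=O)N1NCC[C@H]1C(=O)NCc1cc(Cl)ccc1-n1cnnn1`) gives 1700 nM as its number, a gap beyond the usual scatter.

Compound 3 (`COC(C)(C)[C@@H](O)C(=O)N1[C@H](C(=O)NCc2cc(Cl)ccc2-n2cnnn2)C[C@@H]2C[C@@H]21`) changes one group of compound 1 (1-methoxy-1-methylethyl in place of cyclohexyl on a saturated chain carbon bound to a carbonyl carbon and an oxygen on a saturated carbon): 1-methoxy-1-methylethyl stands in place of cyclohexyl on a saturated chain carbon bound to a carbonyl carbon and an oxygen on a saturated carbon. Within the data shown here, no two measured compounds differ in one place only, so nothing yet shows directly what such a swap does to the number, and this forecast is rough. A modest rise in the number, meaning weaker inhibition, is the expected direction, with an estimated size as shown here (a 2.2-fold higher number from compound 1 to compound 3 (0.34 log units; beyond the scatter)). Compound 3 is expected to give 1300 nM within an estimated range from 400 nM to 4000 nM in this measurement.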

Compound 3, half-maximal inhibitory concentration: 1000 nM
Compound 3: middle estimate off by 1.3-fold (0.11 log units), on the high side, within the range that was stated.
By their numbers in this assay, from the lowest: compounds 1, 3 and 2 (each within the scatter of the next, the first and the last beyond it).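

In this assay, within the data shown here, putting 1-methoxy-1-methylethyl in place of cyclohexyl on this saturated chain carbon gives a 1.7-fold higher number from compound 1 to compound 3 (0.22 log units; within the scatter), the first direct reading of a single change. The six-membered carbon ring can therefore be exchanged here for an open group containing an oxygen, with a hydrogen-bond acceptor added, and the two numbers cannot be told apart. No supporting measurement bears on why this exchange leaves the numbers so close.

Among these compounds, with only one exchange read at this position, it remains open how far its tolerance extends. An amine or a carboxylic acid in the same place, which would bring in a different kind of group, could show whether the number stays within the scatter or moves beyond it.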